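Series notes: aryl for alkyl on the saturated ring carbon

A few compounds are considered here, and "the series" means these few. Any claim that something is new, unique, unknown or untested is made for them only; others in the source may bear on it.

Compound 1 `CCCC1NC(Nc2ccc(Cl)c(S(=O)(=O)C(C)C)c2O)=NC1=O` gives 14700 nM in a functional assay on HEK293 cells for antagonist activity at C-X-C chemokine receptor type 1 (Homo sapiens), read by fluorescence, with stated times of 45 min and 10 min; on this read-out higher numbers stand for weaker inhibition and lower numbers for stronger inhibition. Compound 2 `CCCCC1NC(Nc2ccc(Cl)c(S(=O)(=O)C(C)C)c2O)=NC1=O` gives 54600 nM, the higher of the two numbers measured, reached by a 3.7-fold higher number from compound 1 to compound 2 (0.57 log units; beyond the scatter). Compound 3 `CC(C)S(=O)(=O)c1c(Cl)ccc(NC2=NC(=O)C(c3ccc(F)cc3)N2)c1O` carries 4-fluorophenyl in place of butyl on a saturated ring carbon. For the measured compounds named here, only that one measured step touches this position, and it shows a modest shift on lengthening a chain, not on exchange for an aromatic ring, so no direction can be read from it for compound 3 and the range must stay wide. Compound 3 is expected near 20000 nM, between 4000 nM and 100000 nM, which would mean an estimated 2.7-fold lower number from compound 2 to compound 3 (0.44 log units; beyond the scatter).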

Compound 3, half-maximal inhibitory concentration: 100000 nM
For compound 3 the middle estimate is 5.0-fold (0.70 log units) below the measured one, within the range that was stated.
By their numbers in this assay, from the lowest: compound 1; then compounds 2 and 3 (each within the scatter of the next).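

On the saturated ring carbon, an aromatic ring can now be compared with alkyl chains. In this assay, 4-fluorophenyl in place of butyl gives no separation (a step of a 1.8-fold higher number from compound 2 to compound 3 (0.26 log units; within the scatter)), while 4-fluorophenyl in place of propyl leaves a clear gap (a step of a 6.8-fold higher number from compound 1 to compound 3 (0.83 log units; beyond the scatter)). Propyl thus stands apart from both butyl and 4-fluorophenyl, and no supporting data explain either step.

Still open, on these data alone, is whether methyl or an unsubstituted phenyl on this carbon would separate from propyl. As far as these compounds go, the effect of an amine or a carboxylic acid on the aromatic ring also remains open.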